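Bromo for Trifluoromethyl on a Cytotoxicity Limit

The source may report more compounds than this note shows. Statements on the series, on what has been measured and on what is new or still open speak of the compounds shown alone.

Measured compounds in an ADME assay on J774.1 cells (Mus musculus) for cytotoxicity, read by MTT assay, with a stated time of 48 h; a higher number here means a weaker inhibitor, a lower number a stronger inhibitor:
compound 1 `Cc1nc2ccccn2c1C(=O)N/N=C/c1no[n+]([O-])c1C` gives > 400000 nM;
compound 2 `COc1cc(/C=N/NC(=O)c2no[n+]([O-])c2C)ccc1O` gives > 400000 nM;
compound 3 `Cc1c(C(=O)N/N=C/c2ccc(C(F)(F)F)cc2)no[n+]1[O-]` gives > 400000 nM.

All three values are limits of this assay and not numbers. Compound 3 stands at the limit of > 400000 nM in this assay, at which 3 of the 3 values shown sit, so no numerical result places it in order relative to compound 1 or compound 2, each of which also sits at that limit. No pair of these compounds differs in only one place, so no measured step is available for comparison.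

Compound 4 `Cc1c(C(=O)N/N=C/c2ccc(Br)cc2)no[n+]1[O-]` differs from compound 3 in a single respect: bromo in place of trifluoromethyl on an aromatic carbon. Since compound 3 and every other compound shown report only the limit, there is no measured step that would point to a change in either direction, and a step of no size beyond the scatter is expected here. The expected step of a number no higher from compound 3 to compound 4 (the limit leaves the size open) reflects that view. Compound 4 is therefore expected to give about 400000 nM in this assay, with an estimated range from 200000 nM to 800000 nM, most likely reported again as a limit rather than as a number.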

Compound 4, half-maximal inhibitory concentration: 162000 nM
The estimate for compound 4 lay 2.5-fold (0.39 log units) above the measured number; the whole stated range lies above it.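

In this assay the aromatic carbon para to a large group proves able to register a change, with an at least 2.4-fold lower number from compound 3 to compound 4 (0.39 log units; beyond the scatter) on going to bromo in place of trifluoromethyl. Until now no single-place comparison existed, and only compound 4 gives a number rather than a limit: the limit of > 400000 nM in this assay, at which 3 of the 4 values shown sit. On these data alone, the value of compound 3 is a limit, and the full size of this step therefore remains unknown.

The compounds shown leave open whether chloro or an amine on the same aromatic carbon would also give a lower number than compound 3. Among these compounds, they also leave open whether bromo would produce a similar step on the core of compound 1 or compound 2, and no single pair here can show whether the step is particular to bromo.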